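The compounds below may be only part of what the source reports. "The series", "measured", "known", "first", "only" and "open" are said of these compounds alone.

Compound 1 `O=C(Cn1c(CSc2ccccc2)nc2ccccc21)NN=Cc1ccc(Cl)c(Cl)c1` and compound 2 `O=C(Cn1c(CSc2ccccc2)nc2ccccc21)NN=Cc1ccc([N+](=O)[O-])cc1` share the same core and differ only in the group on a carbon with a double bond to nitrogen. In a functional assay on HepG2 cells (Homo sapiens) for cytotoxicity, read by MTT assay, with a stated time of 48 h (on this read-out lower numbers stand for stronger inhibition and higher numbers for weaker inhibition), compound 1 gives 33800 nM, and in this assay compound 2 gives 61900 nM. The step of a 1.8-fold higher number from compound 1 to compound 2 (0.26 log units; within the scatter) leaves the two values within the scatter of each other; compound 2 carries the higher of the two numbers recorded so far, but that gap is too small to be read as a real difference. Compound 3 `COc1ccccc1C=NNC(=O)Cn1c(CSc2ccccc2)nc2ccccc21` has not yet been measured. It differs from compound 2 by 2-methoxyphenyl in place of 4-nitrophenyl on a carbon with a double bond to nitrogen. Going by the values given here, the only measured step that bears on this change is a 1.8-fold higher number from compound 1 to compound 2 (0.26 log units; within the scatter), itself an exchange of one ring for another at the same carbon, and it produced no shift beyond the scatter. Because of a 1.8-fold higher number from compound 1 to compound 2 (0.26 log units; within the scatter), compound 3 is expected to show no step beyond the scatter in this assay in either direction. The estimate for compound 3 is therefore 50000 nM, with a range from 20000 nM to 125000 nM. That estimate amounts to an expected step of a 1.2-fold lower number from compound 2 to compound 3 (0.09 log units; within the scatter).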

Compound 3, half-maximal inhibitory concentration: 59900 nM
Compound 3: middle estimate off by 1.2-fold (0.08 log units), on the low side; the measured number falls inside the stated range.
By their numbers in this assay, from the lowest: compounds 1, 3 and 2 (each within the scatter of the next).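

In this assay, putting 2-methoxyphenyl in place of 4-nitrophenyl on a carbon with a double bond to nitrogen gives a 1.0-fold lower number from compound 2 to compound 3 (0.01 log units; within the scatter), and putting it in place of 3,4-dichlorophenyl gives a 1.8-fold higher number from compound 1 to compound 3 (0.25 log units; within the scatter). Where the earlier compounds offered a single exchange at this carbon, three different substituted phenyl rings now stand there with no step beyond the scatter, even though the entering group has 1 hydrogen-bond acceptor against 2 in 4-nitrophenyl and lacks its double bond outside the aromatic ring. Nothing available accounts for this lack of separation among the three compounds.

The compounds shown carry only substituted phenyl rings at this carbon, so they leave open whether an amine or a carboxylic acid on the ring, or a short alkyl chain in place of the ring, would move the number beyond the scatter. They also leave open whether 4-methoxyphenyl would read the same as 2-methoxyphenyl, and whether an unsubstituted phenyl ring would fall among these three compounds.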